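This account rests on a few compounds, and the source may have more. Where it says the series, first, only, none or still open, it means among the compounds named here.

Among the measured compounds shown here, compound 2 `O=C(c1cc2ccccc2o1)N1CCC(NCCSC(c2ccc(F)cc2)c2ccc(F)cc2)CC1` is the weaker of the two compounds measured so far in an assay on membranes from Cortex for displacement of a labelled ligand from Sigma non-opioid intracellular receptor 1 (Cavia porcellus), read by scintillation counting, with a stated time of 120 min; on this read-out lower numbers stand for stronger inhibition and higher numbers for weaker inhibition. In this assay compound 2 gives 304 nM. For the measured compounds named here, its only comparator is compound 1 `O=C(c1ccccc1)N1CCC(NCCSC(c2ccc(F)cc2)c2ccc(F)cc2)CC1`, which in this assay gives 2.03 nM; the step of a 150-fold higher number from compound 1 to compound 2 (2.18 log units; beyond the scatter) is the single measured step and is large, beyond the scatter.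

Compound 3 `O=C(C1CC1)N1CCC(NCCSC(c2ccc(F)cc2)c2ccc(F)cc2)CC1` is not yet measured. It differs from compound 2 by cyclopropyl in place of 1-benzofuran-2-yl on a carbonyl carbon. Going by the values given here, the only step that bears on this change is the one from compound 1 to compound 2, which runs the opposite way, from a plain phenyl to 1-benzofuran-2-yl; compound 3 removes that group altogether and puts a small carbocycle in its place. A large step downward is therefore expected, though a return all the way to the number of compound 1 is not assumed, since cyclopropyl is not phenyl. Compound 3 is expected at about 12 nM, with a range of 2.5 nM to 60 nM. The expected step is a 25-fold lower number from compound 2 to compound 3 (1.40 log units; beyond the scatter).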

Compound 3, inhibition constant: 46.4 nM
Beside the measured number, compound 3's estimate is 3.9-fold (0.59 log units) below it; the range from low to high includes it.
By their numbers in this assay, from the lowest: compound 1; then compound 3; then compound 2.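

In this assay, three groups on a carbonyl carbon can now be compared, and phenyl gives the lowest number, ahead of cyclopropyl and then 1-benzofuran-2-yl. Putting cyclopropyl in place of 1-benzofuran-2-yl gives a 6.6-fold lower number from compound 2 to compound 3 (0.82 log units; beyond the scatter), so the high number does not hold for every replacement, yet putting it in place of phenyl gives a 23-fold higher number from compound 1 to compound 3 (1.36 log units; beyond the scatter), so this small carbocycle does not match phenyl at this place. Nothing available accounts for this order.

Going by these compounds, it remains open whether a cyclohexyl or pyridin-2-yl group would stay close to phenyl or fall towards cyclopropyl. On these data alone, it is equally open whether an open-chain isopropyl group would read like cyclopropyl, and whether a benzyl group would be tolerated on the same carbonyl carbon.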